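The source may report more compounds than this note shows. Statements on the series, on what has been measured and on what is new or still open speak of the compounds shown alone.

Working notes on the series, read in a physicochemical assay, read by spectrophotometry, with a stated time of 30 min; on this read-out lower numbers stand for stronger inhibition and higher numbers for weaker inhibition. Going by the values given here, compound 1 `COc1cc(/C=N/NC(=O)CCc2nc3ccccc3c(=O)[nH]2)cc(OC)c1OC` gives 85000000 nM, the lower of the two numbers so far. Compound 2 `COc1cc(/C=N/NC(=O)CCCc2nc3ccccc3c(=O)[nH]2)ccc1O` gives 236000000 nM, a number beyond the scatter from that of compound 1, but the two compounds differ in more than one place, so the pair isolates no single change.

The next compound is compound 3 `COc1cc(/C=N/NC(=O)CCc2nc3ccccc3c(=O)[nH]2)cc(OC)c1O`. The change is hydrogen in place of methyl on an oxygen on an aromatic ring, with hydrogen in place of methyl on an oxygen on an aromatic ring, or methoxy to hydroxy. Among the compounds with values here, no measured pair shows this change, so the expectation is loose. A hydroxy also appears in compound 2 at 236000000 nM, which argues against expecting a large gain. The expected result is a modest shift towards stronger inhibition, a 2.1-fold lower number from compound 1 to compound 3 (0.33 log units; beyond the scatter). For compound 3 the estimate is 40000000 nM, with an expected range of 10000000 nM to 150000000 nM.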

Compound 3, half-maximal inhibitory concentration: 126000000 nM
Estimate against measurement, compound 3: 3.2-fold (0.50 log units) below; measured number inside the range.
By their numbers in this assay, from the lowest: compounds 1, 3 and 2 (each within the scatter of the next, the first and the last beyond it).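

Methoxy to hydroxy at this position gives the first comparison in the series that isolates a single change: in this assay the step is a 1.5-fold higher number from compound 1 to compound 3 (0.17 log units; within the scatter). At this position, hydrogen in place of methyl on an oxygen on an aromatic ring therefore leaves the read-out within the usual scatter, and this assay does not separate compound 1 from compound 3. Going by these compounds alone, nothing measured so far speaks to the reason for this result.

On these data alone, it remains open whether a larger group on that oxygen, such as ethyl or benzyl, or an amine in place of the hydroxy, would carry the number beyond the scatter. As far as these compounds go, compound 2 differs from compound 1 and from compound 3 in more than one place, so the effect of the longer chain alone also remains open.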